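The compounds below may be only part of what the source reports. "The series", "measured", "known", "first", "only" and "open" are said of these compounds alone.

Measured compounds:
- compound 1, `CCCCCCCCCCc1ccc(-c2noc(CC3CCNC3)n2)cc1`: 44%
- compound 2, `CCCCCCCCCCc1ccc(-c2noc(CC(CN)OC(C)=O)n2)cc1`: 0%

In an assay on HeLa cells for inhibition of sphingosine-1-phosphate transporter SPNS2 (Mus musculus), read by LC-MS, tested at 2 uM (on this read-out lower numbers stand for less inhibition and higher numbers for more inhibition at the one concentration tested (going by the name of the read-out)), compound 2 gives 0%, the lowest of the two numbers; its nearest neighbour is compound 1, which gives 44% in this assay. Going by the values given here, the only measured step bearing on the unmeasured compound is the one from compound 1 to compound 2, a number 44 percentage points lower from compound 1 to compound 2 (beyond the scatter), a large drop.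

Compound 3, `CCCCCCCCCCc1ccc(-c2noc([C@@H](N)CCCN)n2)cc1`, differs from compound 2 in one place: a group of 6 heavy atoms (4 carbon, 2 nitrogen; no ring) in place of a group of 8 heavy atoms (5 carbon, 1 nitrogen, 2 oxygen; no ring), on an aromatic carbon. The group that leaves here is the same group whose entry took the inhibition from compound 1 to nothing, and the 1,4-diaminobutyl that enters brings the nitrogen-bearing character back, as in compound 1. A step back upward in this assay is therefore expected, though a single measured step gives little ground for its exact size. For compound 3 the expected step is a number 35 percentage points higher from compound 2 to compound 3 (beyond the scatter). Compound 3 is estimated at 35%, with a range from 5% to 65%.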

Compound 3, a percentage reported as inhibition, at one concentration (the size of the read-out at that concentration, not a potency): 40%
For compound 3 the middle estimate is 5 percentage points below the measured one; the measured number falls inside the stated range.
By their numbers in this assay, from the lowest: compound 2; then compounds 3 and 1 (each within the scatter of the next).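

In this assay, putting 1,4-diaminobutyl on the aromatic carbon gives a number 40 percentage points higher from compound 2 to compound 3 (beyond the scatter), so the reading of compound 2 does not hold for every group at this place on the shared core. The comparison with the ring-bearing group gives a number 4 percentage points lower from compound 1 to compound 3 (within the scatter), which lies within the scatter, so among these compounds a ring in the group at this place is not needed for the inhibition seen with compound 1. Nothing given here explains why these groups read as they do.

On these data alone, it remains open whether each amine of the 1,4-diaminobutyl group counts, which a butyl chain carrying a single amine would show, and whether the defined stereocentre matters. As far as these compounds go, it is also open how a carboxylic acid at this place would read.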